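A few compounds are considered here, and "the series" means these few. Any claim that something is new, unique, unknown or untested is made for them only; others in the source may bear on it.

Compound 1 `CCCCCCCc1ccc(C/C=C/[C@H](SCC(NC(=O)CCC(N)C(=O)O)C(=O)NCC(=O)O)[C@H](O)CCCC(=O)O)cc1`: 574 nM
Compound 2 `CCCCCCCc1cccc(C/C=C/[C@H](SCC(N)C(=O)O)[C@H](O)CCCC(=O)O)c1`: 4830 nM

In a functional assay (trachea) with Cavia porcellus as the target (on this read-out higher numbers stand for an effect only at larger amounts of compound and lower numbers for an effect already at smaller amounts), compound 1 holds the lower of the two numbers at 574 nM. Compound 2 stands higher at 4830 nM, a gap beyond the scatter. The two measured compounds differ in more than one place, so they give no direct guide to a single change.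

The next compound, compound 3 `CCCCCCOc1ccc(C/C=C/[C@H](SCC(NC(=O)CCC(N)C(=O)O)C(=O)NCC(=O)O)[C@H](O)CCCC(=O)O)cc1`, keeps the core of compound 1 and carries hexyloxy in place of heptyl on an aromatic carbon, para to a large group: hexyloxy in place of heptyl on an aromatic carbon.

For the measured compounds named here, with no measured precedent for this swap, no step beyond the scatter is expected in this assay, and no direction is favoured. The expected result is a 1.0-fold higher number from compound 1 to compound 3 (0.02 log units; within the scatter). For compound 3, the estimated value is 600 nM, within an expected range of 200 nM to 1800 nM.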

Compound 3, half-maximal effective concentration: 1280 nM
For compound 3 the middle estimate is 2.1-fold (0.33 log units) below the measured one, within the range that was stated.
By their numbers in this assay, from the lowest: compound 1; then compound 3; then compound 2.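

In this assay, putting hexyloxy in place of heptyl on an aromatic carbon, para to a large group, gives a 2.2-fold higher number from compound 1 to compound 3 (0.35 log units; beyond the scatter). For the compounds shown here, this is the first comparison here that isolates a single place, and it shows that this position registers even a modest change: the group keeps its 7 heavy atoms, yet the swap of one carbon for oxygen, which adds one hydrogen-bond acceptor, moves the number beyond the scatter. Nothing measured here explains the step.

The compounds shown leave open whether a longer chain such as octyl or octyloxy at this carbon would bring the number down or push it up. They also leave open how an amine or a carboxylic acid at the end of the chain would read.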